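The source may hold more compounds than are shown below. What is called first, only, known or untested is meant among the compounds shown, and "the series" means these compounds.

Compound 1 `CCN(CC)CC(=O)N1N=C(C)CC1c1ccccc1O`: 39800 nM
Compound 2 `CC1=NN(C(=O)CN2CCN(C(=O)OC(C)(C)C)CC2)C(c2ccccc2O)C1`: 17600 nM

For the measured compounds named here, in a functional assay on MGC-803 cells (Homo sapiens) for cytotoxicity, read by MTT assay, with a stated time of 48 h (on this read-out higher numbers stand for weaker inhibition and lower numbers for stronger inhibition), compound 2 gives 17600 nM, the lowest of the two numbers so far. Compound 1 stands higher at 39800 nM, a gap that lies beyond the usual scatter. The two compounds differ in more than one place, so this gap cannot be tied to any single structural change.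

Compound 3 `CC1=NN(C(=O)CN2CCN(C)CC2)C(c2ccccc2O)C1` has not yet been measured. It departs from compound 2 at one place, with methyl in place of tert-butoxycarbonyl on an amine nitrogen in a ring, a six-membered non-aromatic ring with 2 nitrogen: methyl in place of tert-butoxycarbonyl on an amine nitrogen in a ring.

Going by the values given here, no measured pair of compounds shows a change at one place, so the only guide is indirect. Compound 1, which carries no tert-butoxycarbonyl, gives 39800 nM. On that slim evidence, a modest move toward weaker inhibition is expected in this assay, near the edge of the scatter, and no real change remains possible. The estimated step is a 1.8-fold higher number from compound 2 to compound 3 (0.26 log units; within the scatter). For compound 3 the expected value is 32000 nM, with an estimated range from 13000 nM to 75000 nM.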

Compound 3, half-maximal inhibitory concentration: 7850 nM
Compound 3: the middle estimate sits 4.1-fold (0.61 log units) above what was measured; measured number below the stated range.
By their numbers in this assay, from the lowest: compound 3; then compound 2; then compound 1.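

In this assay, replacing tert-butoxycarbonyl with methyl on the amine nitrogen in the six-membered ring gives a 2.2-fold lower number from compound 2 to compound 3 (0.35 log units; beyond the scatter), so this position is shown to respond to a change at one place and the larger group is not needed for the inhibition seen here. The second comparison concerns the whole amine on the saturated chain carbon bound to a carbonyl carbon: 4-methylpiperazin-1-yl in place of diethylamino gives a 5.1-fold lower number from compound 1 to compound 3 (0.71 log units; beyond the scatter), leaving compound 3 with the lowest number of the three. Nothing at hand explains why either change goes with stronger inhibition.

With only methyl and tert-butoxycarbonyl on this nitrogen, the compounds shown do not tell whether the trend follows the size of the group, the loss of the carbonyl or something else. Going by these compounds, it also remains open how a free amine, an ethyl group, a longer chain or an acetyl group at this nitrogen would read, and whether any of them would go lower than compound 3.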